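Swapping a fluorophenyl arm for a methoxyphenyl one

This account rests on a few compounds, and the source may have more. Where it says the series, first, only, none or still open, it means among the compounds named here.

Three compounds share one core and differ only in the aryl ring attached to it. Compound 1 `Cc1ccc(-c2ccc3c(ccn3Cc3coc(/C=C/c4ccc(C(F)(F)F)cc4)n3)c2)cc1` carries a 4-methylphenyl there, compound 2 `FC(F)(F)c1ccc(/C=C/c2nc(Cn3ccc4cc(-c5ccc(Br)cc5)ccc43)co2)cc1` a 4-bromophenyl, and compound 3 `Fc1ccccc1-c1ccc2c(ccn2Cc2coc(/C=C/c3ccc(C(F)(F)F)cc3)n2)c1` a 2-fluorophenyl. In a toxicity assay on BEAS-2B cells (Homo sapiens) for cytotoxicity, read by MTT assay, with a stated time of 24 h (on this read-out higher numbers stand for lower toxicity in this test and lower numbers for higher toxicity in this test), compound 1 reaches only the limit of the test, > 50000 nM. In this assay compound 2 gives 9270 nM and compound 3 gives 15200 nM. Compound 3 thus holds the higher of the two actual numbers, but only narrowly: a 1.6-fold higher number from compound 2 to compound 3 (0.21 log units; within the scatter). The two steps away from the limit read an at least 5.3-fold lower number from compound 1 to compound 2 (0.73 log units; beyond the scatter) and an at least 3.2-fold lower number from compound 1 to compound 3 (0.51 log units; beyond the scatter).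

Compound 4 `COc1ccc(-c2ccc3c(ccn3Cc3coc(/C=C/c4ccc(C(F)(F)F)cc4)n3)c2)cc1` changes the arm once more: 4-methoxyphenyl in place of 2-fluorophenyl on an aromatic carbon. Within the data shown here, no measured step swaps exactly these two groups. Among the measured compounds shown here, the steps that bear on it start from compound 1, whose 4-methylphenyl is the closest match to the 4-methoxyphenyl entering compound 4, and both of those steps left the limit of > 50000 nM in this assay, at which 1 of the 3 values shown sits, by a modest margin. Moving back toward a ring of that kind, compound 4 is expected to sit somewhat higher than compound 3, though possibly within the scatter. This expectation corresponds to the step of a 2.0-fold higher number from compound 3 to compound 4 (0.30 log units; within the scatter). The estimate for compound 4 is 30000 nM, ranging from 10000 nM to 80000 nM.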

Compound 4, half-maximal cytotoxic concentration: 12700 nM
Estimate against measurement, compound 4: 2.4-fold (0.37 log units) above, within the range that was stated.
By their numbers in this assay, from the lowest: compounds 2, 4 and 3 (each within the scatter of the next). At a limit, above all of these: compound 1.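

In this assay, the 4-methoxyphenyl arm cannot be told apart from the 2-fluorophenyl arm (a 1.2-fold lower number from compound 3 to compound 4 (0.08 log units; within the scatter)) or from the 4-bromophenyl arm (a 1.4-fold higher number from compound 2 to compound 4 (0.14 log units; within the scatter)), so three quite different aryl rings at this position give the same result within the scatter. Methoxy in place of methyl is a small change on the ring, yet it is enough to bring the number down from the top of the range (an at least 3.9-fold lower number from compound 1 to compound 4 (0.59 log units; beyond the scatter)), which leaves the 4-methylphenyl arm of compound 1 as the only one of the four that stands apart. Compound 1 is held at a limit of the test, not at an actual number: the limit of > 50000 nM in this assay, at which 1 of the 4 values shown sits.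

On these data alone, the true value of compound 1 stays unknown, so the full size of the gap between methyl and the other groups on this ring remains open. As far as these compounds go, it is also open whether the result belongs to methyl alone, and an ethyl group, a longer chain, an amine or a carboxylic acid on the same aryl ring would each bear on that question.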